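The source may hold more compounds than are shown below. What is called first, only, known or untested is meant among the compounds shown, and "the series" means these compounds.

In a functional assay on A549 cells (Homo sapiens) for antiproliferative activity, read by MTT assay, with a stated time of 72 h (a higher number here means a weaker inhibitor, a lower number a stronger inhibitor), compound 1 `Cc1ccc(-c2noc(CCCCCCC(=O)NO)n2)cc1` gives 5810 nM, compound 2 `Cc1ccc(-c2noc(CCCCCCC(=O)Nc3ccccc3N)n2)cc1` gives 9170 nM and compound 3 `O=C(CCCCCCc1nc(-c2ccccc2)no1)C(F)(F)F` gives 7680 nM, so compound 3 lies within the scatter of both others. Compound 4 `Cc1ccc(-c2noc(CCCCCCC(=O)C(F)(F)F)n2)cc1` differs from compound 3 by a single change, methyl in place of hydrogen on an aromatic carbon, which turns phenyl into 4-methylphenyl: methyl in place of hydrogen on an aromatic carbon. Within the data shown here, no measured pair isolates this change. Among the measured compounds shown here, the only measured step, a 1.6-fold higher number from compound 1 to compound 2 (0.20 log units; within the scatter), puts 2-aminophenyl in place of hydroxy on an amide-type nitrogen, stays within the scatter and touches a different part of the molecule. It bears on the question only indirectly: both of its compounds already carry 4-methylphenyl, and their values lie within the scatter of the value of compound 3, which lacks the methyl. Nothing therefore points to a shift beyond the scatter in this assay, and the expected step is a 1.1-fold lower number from compound 3 to compound 4 (0.04 log units; within the scatter). For compound 4 the estimated value is 7000 nM, with an expected range from 3500 nM to 14000 nM.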

Compound 4, half-maximal inhibitory concentration: > 100000 nM
Compound 4: no number, only a limit (the forecaster's own chance of this, stated with the estimate: 4%); at least 14-fold (1.15 log units) between middle value and limit.
By their numbers in this assay, from the lowest: compounds 1, 3 and 2 (each within the scatter of the next). At a limit, above all of these: compound 4.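

Compound 4 gives > 100000 nM in this assay, and this is a limit of the assay, not a number. At this place on the aromatic ring, para to a large group, a single added methyl now gives an at least 13-fold higher number from compound 3 to compound 4 (1.11 log units; beyond the scatter) with trifluoromethyl on the carbonyl carbon, so this position is not indifferent in that pair. The methyl alone does not account for this: 4-methylphenyl is also present with (2-aminophenyl)amino or hydroxyamino on the carbonyl carbon, and the exchange for trifluoromethyl gives an at least 10-fold higher number from compound 2 to compound 4 (1.03 log units; beyond the scatter) and an at least 17-fold higher number from compound 1 to compound 4 (1.23 log units; beyond the scatter) in these pairs.

Going by these compounds, the true size of all three steps stays open, since compound 4 stands at a limit: the limit of > 100000 nM in this assay, at which 1 of the 4 values shown sits. Also open, on these data alone, is how an ethyl or a methoxy group at the same place, or a carboxylic acid in place of trifluoromethyl, would read here.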